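The compounds below may be only part of what the source reports. "The series", "measured", "known", "first", "only" and "open" are said of these compounds alone.

Compound 1 `c1ccc(-c2cn3ccnc3c(-c3ccc4ncn(C5CCCCC5)c4c3)n2)cc1`: 33.3%
Compound 2 `c1cn2cc(-c3ccsc3)nc(-c3ccc4ncn(C5CCCCC5)c4c3)c2n1`: 3.97%

Of the compounds shown here, two sharing one core have been tested in a functional assay on A549 cells (Homo sapiens) for inhibition, read by sulforhodamine B assay, with a stated time of 48 h, tested at 10 uM; a higher number here means more inhibition at the concentration tested (going by the name of the read-out), a lower number less inhibition. Compound 1 gives 33.3%, while compound 2 gives 3.97%. Within the data shown here, compound 2 thus stands lowest of the two numbers; its nearest neighbour is compound 1, and the one measured step, a number 29.3 percentage points lower from compound 1 to compound 2 (beyond the scatter), separates them.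

Compound 3 `Brc1ccc(-c2cn3ccnc3c(-c3ccc4ncn(C5CCCCC5)c4c3)n2)cc1` has not yet been measured. It differs from compound 2 in a single place: 4-bromophenyl in place of thiophen-3-yl on an aromatic carbon. The thiophen-3-yl leaves and a six-membered aromatic ring of carbon only enters again, now bearing bromine. Among the measured compounds shown here, the only measured step bears directly on this change, since a number 29.3 percentage points lower from compound 1 to compound 2 (beyond the scatter) was the move that exchanged phenyl for thiophen-3-yl. Restoring a phenyl ring is therefore expected to recover most of that loss, a modest rise for compound 3 of about a number 26 percentage points higher from compound 2 to compound 3 (beyond the scatter). What the bromine itself contributes is not shown by anything measured here, which widens the range. Compound 3 is estimated to give 30%, within a range of 10% to 55%.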

Compound 3, a percentage reported as inhibition, at one concentration (the size of the read-out at that concentration, not a potency): 15.3%
Beside the measured number, compound 3's estimate is 14.7 percentage points above it; the range from low to high includes it.
By their numbers in this assay, from the lowest: compound 2; then compound 3; then compound 1.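

In this assay, this place on the shared core, on an aromatic carbon next to the ring nitrogen, now proves sensitive to more than the ring itself. Bromo in place of hydrogen on the phenyl group gives a number 18 percentage points lower from compound 1 to compound 3 (beyond the scatter), so a substituent on that ring changes the result even when the ring stays the same. The exchange of thiophen-3-yl for 4-bromophenyl gives a number 11.3 percentage points higher from compound 2 to compound 3 (beyond the scatter), which shows that a six-membered aromatic ring of carbon only improves on thiophen-3-yl here, though the bromo-bearing ring does not reach the value of compound 1, at 33.3%. Nothing available explains why these steps take the size they do.

The compounds shown leave open whether this drop is particular to bromine or would also follow from a fluorine, a methoxy group or an amine on the phenyl ring. They also leave open whether a pyridyl or furan-3-yl ring at this place would behave like phenyl or like thiophen-3-yl, and whether these steps would hold if the cyclohexyl group were replaced by a smaller chain such as ethyl.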